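The compounds below may be only part of what the source reports. "The series", "measured", "known", "first", "only" and "open" are said of these compounds alone.

Series values in a functional assay on HepG2 cells (Homo sapiens) for antiproliferative activity, read by sulforhodamine B assay, with a stated time of 48 h; on this read-out lower numbers stand for stronger inhibition and higher numbers for weaker inhibition

- Compound 1 (`c1ccc(CSc2nc(-c3cc4ccccc4[nH]3)n[nH]2)cc1`) 3.58 ug/mL
- Compound 2 (`c1ccc(CSc2nc(-c3cc4ccccc4[nH]3)nn2Cc2ccccc2)cc1`) 17.9 ug/mL
- Compound 3 (`C=CCn1nc(-c2cc3ccccc3[nH]2)nc1SCc1ccccc1`) 15.9 ug/mL

Compound 3 lies within the scatter of compound 2, as a 1.1-fold lower number from compound 2 to compound 3 (0.05 log units; within the scatter) shows, and well above compound 1, with a 4.4-fold higher number from compound 1 to compound 3 (0.65 log units; beyond the scatter). Compound 4 (`OCCn1nc(-c2cc3ccccc3[nH]2)nc1SCc1ccccc1`) carries hydroxymethyl in place of vinyl on a saturated chain carbon bound to an aromatic nitrogen, that is, allyl to 2-hydroxyethyl (hydroxymethyl in place of vinyl on a saturated chain carbon bound to an aromatic nitrogen). Filling that nitrogen gave a 5.0-fold higher number from compound 1 to compound 2 (0.70 log units; beyond the scatter), but the closest precedent is the change at the chain end, which stayed within the scatter. Within the data shown here, no measured compound carries hydroxymethyl, so the direction remains open and no step beyond the scatter is expected in this assay. The estimated step is a 1.1-fold lower number from compound 3 to compound 4 (0.06 log units; within the scatter). For compound 4 the expected value is 14 ug/mL, with an estimated range of 6 ug/mL to 32 ug/mL.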

Compound 4, half-maximal inhibitory concentration: 12.1 ug/mL
Compound 4: the middle estimate sits 1.2-fold (0.06 log units) above what was measured; measured number inside the range.
By their numbers in this assay, from the lowest: compound 1; then compounds 4, 3 and 2 (each within the scatter of the next).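

In this assay, hydroxymethyl on the saturated chain carbon bound to the aromatic nitrogen reads the same as the two hydrocarbon ends, vinyl with a 1.3-fold lower number from compound 3 to compound 4 (0.12 log units; within the scatter) and phenyl with a 1.5-fold lower number from compound 2 to compound 4 (0.17 log units; within the scatter). The gap to the unsubstituted nitrogen persists with this oxygen-bearing chain, with a 3.4-fold higher number from compound 1 to compound 4 (0.53 log units; beyond the scatter), so benzyl, allyl and 2-hydroxyethyl all sit above compound 1. No evidence on the cause of these numbers is available.

From the compounds shown here alone, whether an amine or a carboxylic acid at the chain end, or a longer chain, would keep that gap remains open.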